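A few compounds are considered here, and "the series" means these few. Any claim that something is new, unique, unknown or untested is made for them only; others in the source may bear on it.

Working notes on the series. Compound 1 `NNC(=O)c1c(N)sc2c1CCCCCC2` and compound 2 `Nc1sc2c(c1C(=O)NNc1ccccc1)CCCCCC2` share one core with compound 3 `NC(=O)c1c(N)sc2c1CCCCCC2` and differ only at the carbonyl-bearing group. In a functional assay on CHO cells for agonist activity at adenosine receptor A1 (Homo sapiens), read by ERK phosphorylation, tested at 3 uM (a lower number here means a weaker effect, a higher number a stronger effect of the compound at the concentration tested), compound 1 gives 48%, compound 2 gives 47% and compound 3 gives 48%. The three steps are all flat: a number 1 percentage points lower from compound 1 to compound 2 (within the scatter), no change at the digits printed from compound 1 to compound 3 (within the scatter) and a number 1 percentage points higher from compound 2 to compound 3 (within the scatter). Among the measured compounds shown here, compound 3 therefore stands level with compound 1 and is separated from compound 2 by nothing beyond the scatter; no compound in the set can be set above another.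

Compound 4 `Nc1sc2c(c1C(=O)c1ccc(Cl)cc1)CCCCCC2` is the next member, differing from compound 3 as follows: 4-chlorophenyl in place of amino on a carbonyl carbon. The measured steps that bear on this are those at the carbonyl substituent, compound 1 to compound 3 and compound 2 to compound 3, where hydrogen, amino and anilino on the amide-type nitrogen all gave the same read-out within the scatter. The new change goes further, since the amino group itself leaves and a 4-chlorophenyl enters on the carbonyl carbon, a move not covered by any measured pair. With every measured step flat, the expected step in this assay is none beyond the scatter, a number 5 percentage points lower from compound 3 to compound 4 (within the scatter), with wide uncertainty. Compound 4 is accordingly estimated at 43%, within the range 20% to 65%.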

Compound 4, a percentage reported as activity, at one concentration (the size of the read-out at that concentration, not a potency): 56%
Compound 4: middle estimate off by 13 percentage points, on the low side, within the range that was stated.
By their numbers in this assay, from the lowest: compounds 2, 1, 3 and 4 (each within the scatter of the next).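

Among the compounds shown here, at the carbonyl carbon, the earlier compounds varied only the group on an amide-type nitrogen, whereas compound 4 has no such nitrogen: in this assay, 4-chlorophenyl in place of amino gives a number 8 percentage points higher from compound 3 to compound 4 (within the scatter), and 4-chlorophenyl in place of aminoamino gives a number 8 percentage points higher from compound 1 to compound 4 (within the scatter). This position therefore accepts the loss of the amino group and the entry of a six-membered aromatic ring of carbon only, with a read-out that cannot be separated from those of the amide and the hydrazide-type compounds. Nothing available explains this outcome.

On these data alone, it remains open whether any group on this carbonyl carbon can move the read-out beyond the scatter, and whether the chlorine contributes at all; a plain phenyl would address the second question, while a hydroxyl or a methyl on the same carbon would extend the first. Because the read-out is taken at a single concentration and is not a potency, the relative potencies of these compounds also remain open.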